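Longer Chain on a Cytotoxicity Limit

The source may hold more compounds than are shown below. What is called first, only, known or untested is meant among the compounds shown, and "the series" means these compounds.

Compound 2 `CCCCCCNc1cncc(C(=O)NCc2ccccc2)n1` was tested in an ADME assay on HEL cells (Homo sapiens) for cytotoxicity, read by microscopy, with a stated time of 6 days; a lower number here means that less compound is tolerated, a higher number that more compound is tolerated. In this assay compound 2 gives > 100000 nM, which is a limit of the assay rather than a number. Compound 1 `CCCCNc1cnc(C(=O)NCc2ccccc2)cn1` reaches the same kind of limit, giving > 100000 nM in this assay. Compound 3 `CCCCNc1nccnc1C(=O)NCc1ccccc1` likewise returns > 100000 nM in this assay, again a limit. Among the compounds with values here, every value here therefore sits at the limit of > 100000 nM in this assay, at which 3 of the 3 values shown sit, and no measured step between these compounds can be drawn. Compound 4 `CCCCCCCCNc1cncc(C(=O)NCc2ccccc2)n1` has not yet been tested; it differs from compound 2 by ethyl in place of hydrogen on a saturated chain carbon, six bonds along the chain from a nitrogen on an aromatic ring. With all three measured compounds at the limit, no step beyond the scatter is expected in this assay. Compound 4 is expected to give 100000 nM, within 30000 nM to 300000 nM. The expected step is a number no higher from compound 2 to compound 4 (the limit leaves the size open), none beyond the scatter.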

Compound 4, minimum cytotoxic concentration: > 100000 nM
Compound 4 was reported as a limit (the forecaster's own chance of this, stated with the estimate: 70%); the middle value lies on the limit itself.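

No step can be read from compound 2 to compound 4, because both results in this assay are limits rather than numbers: the limit of > 100000 nM in this assay, at which 4 of the 4 values shown sit.

The compounds shown leave open whether the length of the chain affects cytotoxicity at all.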